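Trading an Ester for an Amine on Compound 1

A few compounds are considered here, and "the series" means these few. Any claim that something is new, unique, unknown or untested is made for them only; others in the source may bear on it.

Going by the values given here, compound 1 `CCOC(=O)c1cccc(-c2ccc(N(C)C)cc2)c1` gives 40000 nM in an assay on COS-7 cells for inhibition of patatin-like phospholipase domain-containing protein 2 (Mus musculus) (a lower number here means a stronger inhibitor, a higher number a weaker inhibitor), the lowest of the two numbers measured so far. Among the compounds with values here, its nearest neighbour is compound 2 `CCOC(=O)c1cccc(-c2ccc(C(C)=O)cc2)c1`, which gives 200000 nM in this assay; the only measured step, a 5.0-fold higher number from compound 1 to compound 2 (0.70 log units; beyond the scatter), arises from acetyl in place of dimethylamino on an aromatic carbon.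

Compound 3 `CN(C)c1ccc(-c2cccc(N)c2)cc1` has not yet been measured. It differs from compound 1 by amino in place of ethoxycarbonyl on an aromatic carbon. Within the data shown here, the single measured step concerns the other ring of the shared core and says nothing about the ethoxycarbonyl side, so there is no measured guide to this change, and no step beyond the scatter is expected in either direction, though the uncertainty is wide. Compound 3 is therefore estimated at 60000 nM, with a range from 15000 nM to 250000 nM. That estimate corresponds to an expected step of a 1.5-fold higher number from compound 1 to compound 3 (0.18 log units; within the scatter).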

Compound 3, half-maximal inhibitory concentration: 100000 nM
Compound 3: middle estimate off by 1.7-fold (0.22 log units), on the low side; the range from low to high includes it.
By their numbers in this assay, from the lowest: compound 1; then compounds 3 and 2 (each within the scatter of the next).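

Going by these compounds alone, this is the first measured change on the ethoxycarbonyl side of the shared core, and in this assay replacing that group with amino gives a 2.5-fold higher number from compound 1 to compound 3 (0.40 log units; beyond the scatter) in this modest step. The position therefore does respond to what sits on it, and compound 1 remains the lowest of the three, with its steps to both others printed as beyond the scatter. No measurement is available to explain why the number rises.

With only one replacement shown here, the compounds cannot separate the effect of losing the ethoxycarbonyl group from that of gaining the amino group. A carboxylic acid, a methyl ester or a primary amide on the same aromatic carbon would show whether any group here can bring the number below that of compound 1.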